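The compounds below may be only part of what the source reports. "The series", "measured", "known", "first", "only" and "open" are said of these compounds alone.

In a functional assay on aorta for antagonist activity at Alpha-1D adrenergic receptor (Rattus norvegicus) (a lower number here means tighter binding, a higher number weaker binding), compound 2 `CN(C)C(=O)c1cccnc1NCCCN1CCN(c2ccccc2C2CC2)CC1` gives 63.1 nM, the highest of the two numbers measured here; its nearest neighbour, compound 1 `CN(C)C(=O)c1cccnc1NCCCN1CCN(c2ccccc2C#N)CC1`, gives 10 nM. Among the compounds with values here, the one measured step, a 6.3-fold higher number from compound 1 to compound 2 (0.80 log units; beyond the scatter), concerns a change on an aromatic carbon. Compound 3 `COc1cc(O)ccc1N1CCN(CCCNc2ncccc2C(=O)N(C)C)CC1` differs from compound 2 in another place: 4-hydroxy-2-methoxyphenyl in place of 2-cyclopropylphenyl on an amine nitrogen in a ring. Within the data shown here, no measured step bears directly on this change, so the expectation rests on little. Compound 3 is estimated at 30 nM, with a range from 5 nM to 200 nM, an expected step of a 2.1-fold lower number from compound 2 to compound 3 (0.32 log units; beyond the scatter) in this assay.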

Compound 3, dissociation constant: 79.4 nM
Beside the measured number, compound 3's estimate is 2.6-fold (0.42 log units) below it; low and high end bracket the measured number.
By their numbers in this assay, from the lowest: compound 1; then compounds 2 and 3 (each within the scatter of the next).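

In this assay, replacing 2-cyclopropylphenyl with 4-hydroxy-2-methoxyphenyl on the ring amine nitrogen gives a 1.3-fold higher number from compound 2 to compound 3 (0.10 log units; within the scatter), so these two groups, despite their different hydrogen-bond donor and acceptor counts, cannot be told apart here. Within the data shown here, replacing 2-cyanophenyl with the same group gives a 7.9-fold higher number from compound 1 to compound 3 (0.90 log units; beyond the scatter), which leaves 2-cyanophenyl as the only one of the three groups with a clearly separate number. Nothing available here accounts for either step. Going by these compounds, the separate contributions of the hydroxy and methoxy groups remain open, as does what an unsubstituted phenyl group on this nitrogen would give.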